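The compounds below may be only part of what the source reports. "The series", "measured", "known", "first", "only" and "open" are said of these compounds alone.

Measured in a functional assay on LNCaP cells (Homo sapiens) for antiproliferative activity, read by propidium iodide staining, with a stated time of 96 h; a higher number here means a weaker inhibitor, a lower number a stronger inhibitor:
compound 1 `CC(O)(CSc1ccc(OC(F)(F)F)cc1)C(=O)Nc1ccc(S(F)(F)(F)(F)F)cc1` gives 16100 nM
compound 2 `CC1(C)C(=O)N(c2ccc([N+](=O)[O-])c(C(F)(F)F)c2)C(=S)N1c1cccc(S(F)(F)(F)(F)F)c1` gives 100000 nM

Of these two, compound 2 stands highest, and its gap to compound 1 lies beyond the scatter. Compound 3 `CC1(C)C(=O)N(c2ccc(C#N)c(C(F)(F)F)c2)C(=S)N1c1cccc(S(F)(F)(F)(F)F)c1` has cyano in place of nitro on an aromatic carbon, ortho to a trifluoromethyl group (cyano in place of nitro on an aromatic carbon). Among the measured compounds shown here, no measured pair shows this change, so the expectation is tentative. In this assay a step to a lower number, beyond the scatter, is expected, since compound 2 starts from 100000 nM. The expected step is a 3.3-fold lower number from compound 2 to compound 3 (0.52 log units; beyond the scatter). The estimate for compound 3 is 30000 nM, with an expected range of 8000 nM to 100000 nM.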

Compound 3, half-maximal inhibitory concentration: 6900 nM
Compound 3: middle estimate off by 4.3-fold (0.64 log units), on the high side, outside the stated range (below it).
By their numbers in this assay, from the lowest: compound 3; then compound 1; then compound 2.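

Cyano in place of nitro on this aromatic carbon, ortho to a trifluoromethyl group and para to a large group, gives a 14-fold lower number from compound 2 to compound 3 (1.16 log units; beyond the scatter) in this assay. Among the compounds shown here, this is the first comparison that differs in one place, and it shows that the group at this position strongly affects the read-out. Nothing available accounts for the size of this step. Open, as far as these compounds go, is how a carboxylic acid or an amine on this carbon would compare with cyano, and whether the step carries over to other substituents elsewhere on the shared core.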